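The source may hold more compounds than are shown below. What is called first, only, known or untested is meant among the compounds shown, and "the series" means these compounds.

Working notes on the amide side chains of the shared core, read in a functional assay on PC-3 cells (Homo sapiens) for antiproliferative activity, read by MTT assay, with a stated time of 24 h; on this read-out lower numbers stand for stronger inhibition and higher numbers for weaker inhibition. Compound 1 (`CCn1c(C(=O)NCC(=O)OC)ccc1C(CC)(CC)c1ccc(OCS(=O)(=O)c2ccccc2)c(C)c1`) gives > 50000 nM and this is a limit of the assay, not a number. Compound 2 (`CCn1c(C(=O)N[C@H](C)C(=O)OC)ccc1C(CC)(CC)c1ccc(OCS(=O)(=O)c2ccccc2)c(C)c1`) gives > 50000 nM and this too is a limit. Among the measured compounds shown here, compound 3 (`CCn1c(C(=O)NCCN)ccc1C(CC)(CC)c1ccc(OCS(=O)(=O)c2ccccc2)c(C)c1`) at 6890 nM holds the only actual number so far, and it alone carries the 2-aminoethyl group.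

Compound 4 (`CCn1c(C(=O)N[C@H](C)CO)ccc1C(CC)(CC)c1ccc(OCS(=O)(=O)c2ccccc2)c(C)c1`) has 1-(hydroxymethyl)ethyl in place of 2-aminoethyl on an amide-type nitrogen. For the measured compounds named here, it therefore gives up the group found only in the one compound with a number. Going by the values given here, two measured steps bear on this: an at least 7.2-fold lower number from compound 1 to compound 3 (0.86 log units; beyond the scatter) and an at least 7.2-fold lower number from compound 2 to compound 3 (0.86 log units; beyond the scatter). Both are lower bounds on what the 2-aminoethyl group gained, while a step that the two limits leave unreadable from compound 1 to compound 2 adds nothing. In this assay a move to a higher number is therefore expected, though a hydroxyl-bearing chain has not been tested here. The expected step is a 4.1-fold higher number from compound 3 to compound 4 (0.61 log units; beyond the scatter) and it may end at the limit. For compound 4 the estimated value is 28000 nM with an expected range of 10000 nM to 50000 nM as the likely span.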

Compound 4, half-maximal inhibitory concentration: 7790 nM
Compound 4: middle estimate off by 3.6-fold (0.56 log units), on the high side, and the stated range ends above it.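

At this amide-type nitrogen, the 2-aminoethyl group is not the only side chain that gives a measurable value in this assay: 1-(hydroxymethyl)ethyl in its place gives a 1.1-fold higher number from compound 3 to compound 4 (0.05 log units; within the scatter), so the two chains cannot be told apart. The separation from the methoxycarbonyl-bearing chains is thus shared by a hydroxyl-bearing chain, with an at least 6.4-fold lower number from compound 2 to compound 4 (0.80 log units; beyond the scatter) and an at least 6.4-fold lower number from compound 1 to compound 4 (0.80 log units; beyond the scatter). Compound 1 and compound 2 remain limits of the assay, not numbers, so both of these steps are lower bounds: the limit of > 50000 nM in this assay, at which 2 of the 4 values shown sit.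

On these data alone, it remains open how a carboxylic acid or a plain isopropyl group would read at this nitrogen, and so whether the hydroxyl or the amine contributes at all. The opposite configuration of the defined stereocentre in compound 4 also lies outside the compounds shown.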